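The source may report more compounds than this note shows. Statements on the series, on what has been measured and on what is new or still open speak of the compounds shown alone.

Measured so far in a physicochemical assay for lipophilicity, read by HPLC, at pH 7.5; on this read-out lower numbers stand for lower lipophilicity and higher numbers for higher lipophilicity:
compound 1 `CC[C@@H](Nc1c(C#N)c(-c2ccc(-c3ncccc3C)cc2)nc2cnccc12)C(N)=O` gives 2;
compound 2 `CCOc1ccccc1-c1ccc(-c2nc3cnccc3c(NC(C(N)=O)C3CC3)c2C#N)cc1` gives 3;
compound 3 `CCOc1ccccc1-c1ccc(-c2nc3cnccc3c(N[C@@H]3CCOC3=O)c2C#N)cc1` gives 2.7.

Compound 1 stands lowest of the three in this assay: compound 3 is the nearest above it and compound 2 the furthest, both beyond the scatter. Among the compounds with values here, the only measured step between compounds that differ in a single place runs from compound 2 to compound 3, with a number 0.30 log units lower from compound 2 to compound 3 (within the scatter), a change on a nitrogen on an aromatic ring. Compound 4 `CC[C@@H](Nc1c(C#N)c(-c2ccc(-c3ccccc3Cl)cc2)nc2cnccc12)C(N)=O` differs from compound 1 in a different place: 2-chlorophenyl in place of 3-methylpyridin-2-yl on an aromatic carbon. Within the data shown here, no measured step touches that place, so the expectation rests on the change itself rather than on a measured pair. From compound 1, the number for compound 4 is expected to rise by a number 1.20 log units higher from compound 1 to compound 4 (beyond the scatter). Compound 4 is therefore estimated at 3.2, between 2.6 and 3.8.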

Compound 4, distribution coefficient: 2.9
Compound 4: the middle estimate sits 0.30 log units above what was measured; the measured number falls inside the stated range.
By their numbers in this assay, from the lowest: compound 1; then compounds 3, 4 and 2 (each within the scatter of the next).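

In this assay, within the data shown here, putting 2-chlorophenyl in place of 3-methylpyridin-2-yl gives a number 0.90 log units higher from compound 1 to compound 4 (beyond the scatter) as the first measured step at this aromatic carbon. It shows that the read-out can move beyond the scatter here, even though both groups hold 7 heavy atoms and differ in that the ring nitrogen and methyl give way to a chlorine. Nothing available accounts for the size of this step.

This one pair changes the ring atom and the substituent together, leaving their separate contributions unresolved. On these data alone, how a plain phenyl or a 2-methylphenyl group would read at this position remains open.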